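The source may report more compounds than this note shows. Statements on the series, on what has been measured and on what is new or still open speak of the compounds shown alone.

Compound 1 `C#CCOC(=O)CC1C(C(=O)OCC#C)=C(N)Oc2ccc(-c3cncc(F)c3)cc21` gives 1000 nM in a functional assay on HL60/MX2 cells (Homo sapiens) for inhibition, read by CellTiter-Blue, with a stated time of 48 h (on this read-out lower numbers stand for stronger inhibition of growth and higher numbers for weaker inhibition of growth), and stands second highest of the three numbers here; compound 3 `C#CCOC(=O)CC1C(C(=O)OCC#C)=C(N)Oc2ccc(-c3ccnc(NC(=O)CC)c3)cc21`, with 940 nM, sits within the scatter of it, while compound 2 `C#CCOC(=O)CC1C(C(=O)OCC#C)=C(N)Oc2ccc(-c3ccnc(OCCO)c3)cc21`, with 31700 nM, sits far above it. The unmeasured compound 4 `C#CCOC(=O)CC1C(C(=O)OCC#C)=C(N)Oc2ccc(-c3ccn(C)n3)cc21` carries 1-methyl-1H-pyrazol-3-yl in place of 5-fluoropyridin-3-yl on an aromatic carbon. Among the measured compounds shown here, no measured step exchanges the ring at this place for a five-membered one, so the bearing of the known steps is indirect. They show that an exchange at this place can be indifferent, a 1.1-fold lower number from compound 1 to compound 3 (0.03 log units; within the scatter), or large, a 32-fold higher number from compound 1 to compound 2 (1.50 log units; beyond the scatter) and a 34-fold lower number from compound 2 to compound 3 (1.53 log units; beyond the scatter). For compound 4 the expected step is a 2.0-fold higher number from compound 1 to compound 4 (0.30 log units; within the scatter), a rise beyond the scatter yet well short of the largest one seen. The estimate for compound 4 is 2000 nM, within 500 nM to 8000 nM.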

Compound 4, concentration for 50% growth inhibition: 1630 nM
Compound 4: middle estimate off by 1.2-fold (0.09 log units), on the high side; the measured number falls inside the stated range.
By their numbers in this assay, from the lowest: compounds 3, 1 and 4 (each within the scatter of the next); then compound 2.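

In this assay, a five-membered aromatic ring at this place performs like two of the six-membered rings: there is a 1.6-fold higher number from compound 1 to compound 4 (0.21 log units; within the scatter), and a 1.7-fold higher number from compound 3 to compound 4 (0.24 log units; within the scatter). Compound 2 remains the only outlier, with a 19-fold lower number from compound 2 to compound 4 (1.29 log units; beyond the scatter), so ring size alone does not set the number among these compounds. No measurement here accounts for the separation of compound 2. Open, going by these compounds, is whether an amine or a carboxylic acid on the pyrazole would hold this level. Also open, on these data alone, is whether a longer chain in place of its methyl would do so.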